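The source may report more compounds than this note shows. Statements on the series, on what has been measured and on what is new or still open speak of the compounds shown alone.

Compound 1, `CC1CCN(C2CCN(S(=O)(=O)c3cccc(C(F)(F)F)c3)CC2)CC1`: > 5000 nM
Compound 2, `CC1CCN(C2CCN(S(=O)(=O)c3ccc(-c4ccccc4)cc3)CC2)CC1`: > 5000 nM
Compound 3, `CC1CCN(C2CCN(S(=O)(=O)c3ccc(-c4ccc(Cl)cc4)cc3)CC2)CC1`: > 5000 nM

In an ADME assay on HCT-116 cells (Homo sapiens) for cytotoxicity, read by CellTiter-Glo, with a stated time of 72 h (a lower number here means a stronger inhibitor, a higher number a weaker inhibitor), compound 1 gives only a limit, > 5000 nM. Compound 2 likewise gives only a limit, > 5000 nM. Compound 3 too gives only a limit, > 5000 nM. All three values sit at the limit of > 5000 nM in this assay, at which 3 of the 3 values shown sit. How the core of compound 1 differs from that of compound 2 is not broken down here. From compound 2 to compound 3 the change is chloro in place of hydrogen on an aromatic carbon; the step it made, a step that the two limits leave unreadable from compound 2 to compound 3, cannot be read because both values sit at the limit of > 5000 nM in this assay, at which 3 of the 3 values shown sit.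

Compound 4, `CC1CCN(C2CCN(S(=O)(=O)c3ccc(Cl)c(C(F)(F)F)c3)CC2)CC1`, has not yet been measured in this assay. From compound 1 to compound 4 the change is chloro in place of hydrogen on an aromatic carbon, the same kind of change as before, though here the place is ortho to a trifluoromethyl group as well as para to a large group. Since compound 1 shows only a limit in this assay, the step from compound 1 to compound 4 is expected to be about a step that the limit leaves unreadable from compound 1 to compound 4, most likely leaving compound 4 at a limit again. Compound 4 is therefore estimated at 10000 nM, between 3000 nM and 30000 nM.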

Compound 4, half-maximal inhibitory concentration: > 5000 nM
Compound 4: only a limit was reported; the forecaster's own chance of this, stated with the estimate: 85%; the middle value does not contradict the limit.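

Compound 1 and compound 4 both give only a limit, so the step between them in this assay cannot be read: the limit of > 5000 nM in this assay, at which 4 of the 4 values shown sit.

The compounds shown leave open what true value lies behind each limit, and whether chloro in place of hydrogen changes it at all.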